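A few compounds are considered here, and "the series" means these few. Any claim that something is new, unique, unknown or untested is made for them only; others in the source may bear on it.

Three compounds share one core and differ only in the group on the amide-type nitrogen. In an assay on isolated protein for inhibition of glutathione S-transferase P (Homo sapiens), with a stated time of 10 min (on this read-out higher numbers stand for weaker inhibition and lower numbers for stronger inhibition), compound 1 `O=C(CCC(=O)OCCCCCCSc1ccc([N+](=O)[O-])c2nonc12)Nc1ccccc1Cl` gives 15500 nM. Compound 2 `O=C(CCC(=O)OCCCCCCSc1ccc([N+](=O)[O-])c2nonc12)Nc1cccc(Cl)c1` gives 28800 nM in this assay, the highest of the three numbers, though the step of a 1.9-fold higher number from compound 1 to compound 2 (0.27 log units; within the scatter) stays within the scatter. Compound 3 `COc1ccc(NC(=O)CCC(=O)OCCCCCCSc2ccc([N+](=O)[O-])c3nonc23)cc1OC` gives 6470 nM; the step of a 4.5-fold lower number from compound 2 to compound 3 (0.65 log units; beyond the scatter) is modest but beyond the scatter, as is a 2.4-fold lower number from compound 1 to compound 3 (0.38 log units; beyond the scatter). Compound 4 `O=C(CCC(=O)OCCCCCCSc1ccc([N+](=O)[O-])c2nonc12)Nc1ccc(F)c(Cl)c1` is not yet measured and differs from compound 2 by fluoro in place of hydrogen on an aromatic carbon. Going by the values given here, none of the measured steps covers such an addition; each only swaps the whole group. The expected step is therefore small, a 1.2-fold lower number from compound 2 to compound 4 (0.06 log units; within the scatter), none beyond the scatter. For compound 4 the estimate in this assay is 25000 nM, between 10000 nM and 60000 nM.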

Compound 4, half-maximal inhibitory concentration: 9850 nM
Compound 4: the middle estimate sits 2.5-fold (0.40 log units) above what was measured, and the stated range ends above it.
By their numbers in this assay, from the lowest: compounds 3, 4, 1 and 2 (each within the scatter of the next, the first and the last beyond it).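

In this assay, a single fluoro on the aromatic carbon ortho to a chloro group produces a modest step beyond the scatter (a 2.9-fold lower number from compound 2 to compound 4 (0.47 log units; beyond the scatter)), so this position responds to one added atom, which the swaps of whole groups could not show. The 3-chloro-4-fluorophenyl group stays within the scatter of the other two groups (a 1.5-fold higher number from compound 3 to compound 4 (0.18 log units; within the scatter); a 1.6-fold lower number from compound 1 to compound 4 (0.20 log units; within the scatter)). Nothing available explains the step.

On these data alone, how an amine or a carboxylic acid on that same carbon would read remains open. So does whether fluoro would act alike on the 2-chlorophenyl group.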